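This account rests on a few compounds, and the source may have more. Where it says the series, first, only, none or still open, it means among the compounds named here.

Compound 1, with the structure `CN1CCN(c2ccc3[nH]nc(S(=O)(=O)c4ccccc4Cl)c3c2)CC1`, gives 101 nM in a functional assay on HeLa cells for antagonist activity at 5-hydroxytryptamine receptor 6 (Homo sapiens); a higher number here means a weaker inhibitor, a lower number a stronger inhibitor. Among the three measured compounds it has the highest number. Compound 2, `Cn1nc(S(=O)(=O)c2ccccc2)c2cc(N3CCNCC3)ccc21`, gives 3.2 nM, and compound 3, `CCn1nc(S(=O)(=O)c2cccc3ccccc23)c2cc(N3CCN(C)CC3)ccc21`, gives 1.7 nM; both of these numbers lie below that of compound 1 by more than the usual scatter. Compound 4, `CN1CCN(c2ccc3[nH]nc(S(=O)(=O)c4ccc(F)cc4)c3c2)CC1`, has not yet been measured. It differs from compound 1 in one place: 4-fluorophenyl in place of 2-chlorophenyl on a sulfonyl sulfur. Going by the values given here, no measured pair shows this change, so the expected step from compound 1 to compound 4 is estimated at a 2.5-fold lower number from compound 1 to compound 4 (0.40 log units; beyond the scatter), towards a lower number. Compound 4 is therefore expected to give about 40 nM, within a range from 10 nM to 160 nM.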

Compound 4, half-maximal inhibitory concentration: 467 nM
Compound 4: the middle estimate sits 12-fold (1.07 log units) below what was measured, and the stated range ends below it.
By their numbers in this assay, from the lowest: compounds 3 and 2 (each within the scatter of the next); then compound 1; then compound 4.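

Going by these compounds alone, compound 1 and compound 4 are the first pair here that differ only in the group on the sulfonyl sulfur, and 4-fluorophenyl in place of 2-chlorophenyl gives a 4.6-fold higher number from compound 1 to compound 4 (0.66 log units; beyond the scatter) with the rest of the molecule unchanged. The number therefore responds to this position alone, and this change moves it towards a weaker inhibitor. No measurement at hand explains the step.

The change swaps the halogen and its place on the ring together, so the two effects remain unseparated. As far as these compounds go, how a plain phenyl group would behave on this core also stays open.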